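The compounds below may be only part of what the source reports. "The series", "measured", "known", "first", "only" and "open" are said of these compounds alone.

Measured in an ADME assay on Huh-7 cells (Homo sapiens) for cytotoxicity, read by MTT assay, with a stated time of 96 h; a higher number here means that more compound is tolerated, a lower number that less compound is tolerated:
- Compound 1 `COc1cc(/N=C/c2cccs2)ccc1-c1cnco1`: > 100000 nM (a limit)
- Compound 2 `COc1cc(NCc2ccc(Cl)s2)ccc1-c1cnco1`: 43200 nM

Among the compounds with values here, compound 2, at 43200 nM, carries the only actual number in the set. The entry for compound 1 is a limit of the assay and not a number: the limit of > 100000 nM in this assay, at which 1 of the 2 values shown sits.

The next compound is compound 3 `CCc1ccc(CNc2ccc(-c3cnco3)c(OC)c2)s1`, which keeps the scaffold of compound 2 and alters one substituent, 5-chlorothiophen-2-yl to 5-ethylthiophen-2-yl: ethyl in place of chloro on an aromatic carbon. The swap, ethyl in place of chloro, sits on an aromatic carbon next to the ring sulfur.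

Within the data shown here, no step between measured compounds that differ in one place is available, so the expectation rests on compound 2 at 43200 nM alone. In this assay, no shift beyond the usual scatter is expected, and no direction is favoured with any confidence. The expected change is a 1.0-fold higher number from compound 2 to compound 3 (0.02 log units; within the scatter). For compound 3 the estimated half-maximal cytotoxic concentration is 45000 nM, with an expected range of 18000 nM to 100000 nM.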

Compound 3, half-maximal cytotoxic concentration: 39100 nM
Compound 3: middle estimate off by 1.2-fold (0.06 log units), on the high side, and the stated range covers the measured number.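

Notes on the thiophene position: on this aromatic carbon next to the ring sulfur, ethyl in place of chloro gives a 1.1-fold lower number from compound 2 to compound 3 (0.04 log units; within the scatter) in this assay, which is the first step that can be read in the series. With that step inside the scatter, this assay does not separate the chloro of the 5-chlorothiophen-2-yl group from the ethyl of the 5-ethylthiophen-2-yl group, so at this position a chlorine is not needed for a number of the size seen for compound 2, and a carbon chain of two heavy atoms serves as well as a single chlorine. The data at hand offer no measured property that bears on this step.

As far as these compounds go, whether any group on this carbon can move the number beyond the scatter stays open, and a carboxylic acid, a primary amine or a chain longer than ethyl would each test that. One pair also leaves open whether ethyl in place of chloro reads the same way on another carbon of the thiophene or on a different core.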